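The source may hold more compounds than are shown below. What is called first, only, known or untested is meant among the compounds shown, and "the series" means these compounds.

Compound 2 `C=CC(=O)N1CC[C@H](N2C(=O)N(c3ccccc3)Cc3cnc(Nc4ccc(C5CCN(C)CC5)cc4)nc32)C1` and compound 1 `C=CC(=O)N1CC[C@H](N2C(=O)N(c3ccccc3)Cc3cnc(Nc4ccc(N5CCN(C)CC5)c(OC)c4)nc32)C1` were both run in an ADME assay on the whole organism (strain Sprague-Dawley) for pharmacokinetics, with Rattus norvegicus as the target, read by LC-MS, at a dose of 25 mg/kg by the oral route; on this read-out higher numbers stand for fast clearance and lower numbers for slow clearance. Compound 1 gives 467 mL/min/kg. Compound 2 stands at 335 mL/min/kg, its nearest neighbour being compound 1, and the gap between the two sits within the usual scatter of this assay. Compound 3 `C=CC(=O)N1CC[C@H](N2C(=O)N(c3ccccc3)Cc3cnc(Nc4ccc(N5CCN(C)CC5)cc4)nc32)C1` has not been measured. It differs from compound 2 by 4-methylpiperazin-1-yl in place of 1-methylpiperidin-4-yl on an aromatic carbon. No measured step of this kind exists among these compounds, so the expected step is one of no change beyond the scatter, a 1.2-fold higher number from compound 2 to compound 3 (0.08 log units; within the scatter). Compound 3 is therefore estimated at 400 mL/min/kg, within a range from 200 mL/min/kg to 800 mL/min/kg.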

Compound 3, clearance in the Rattus norvegicus assay: 203 mL/min/kg
The estimate for compound 3 lay 2.0-fold (0.29 log units) above the measured number; low and high end bracket the measured number.
By their numbers in the Rattus norvegicus assay, from the lowest: compounds 3, 2 and 1 (each within the scatter of the next, the first and the last beyond it).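

In the Rattus norvegicus assay, 4-methylpiperazin-1-yl in place of 1-methylpiperidin-4-yl gives a 1.7-fold lower number from compound 2 to compound 3 (0.22 log units; within the scatter), while hydrogen in place of methoxy gives a 2.3-fold lower number from compound 1 to compound 3 (0.36 log units; beyond the scatter). In a physicochemical assay for solubility, read by HPLC, in phosphate buffer, measured as thermodynamic solubility, with a stated time of 24 h, at pH 6.8 (on this read-out lower numbers stand for lower solubility and higher numbers for higher solubility), compound 2 gives 310 ug/mL and compound 3 gives 976 ug/mL. The change of ring on this aromatic carbon therefore shows a clear step in solubility, though not in clearance: the measured solubility of compound 2, 310 ug/mL, and of compound 3, 976 ug/mL, a 3.1-fold higher number (0.50 log units; beyond the scatter)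

Still open, going by these compounds, is how a morpholine ring on the same aromatic carbon would read in either assay. Also open, on these data alone, is whether hydrogen in place of methoxy gives a similar step when 1-methylpiperidin-4-yl is present.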